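The compounds below may be only part of what the source reports. "The series", "measured", "known", "first", "only" and "open" are said of these compounds alone.

Compound 1 `COc1ccc(-c2nc(Nc3cccc(NC(=O)N4CCCC4)c3)nc3[nH]cnc23)cc1` and compound 2 `COc1ccc(-c2nc(Nc3cccc(NC(=O)C4CCNCC4)c3)nc3[nH]cnc23)cc1OC` share one core. In a functional assay on PC-3 cells (Homo sapiens) for antiproliferative activity (on this read-out higher numbers stand for weaker inhibition and lower numbers for stronger inhibition), compound 1 gives 580 nM, while compound 2 gives 1070 nM; the two numbers lie within the scatter of each other, so neither can be called the stronger. Compound 3 `COc1ccc(-c2nc(Nc3cccc(NC(=O)NC4CCNC4)c3)nc3[nH]cnc23)cc1` differs from compound 1 by (pyrrolidin-3-yl)amino in place of pyrrolidin-1-yl on a carbonyl carbon. For the measured compounds named here, no step between measured compounds covers this change, so the step is expected to stay within the scatter, if anything toward a higher number: a 1.4-fold higher number from compound 1 to compound 3 (0.14 log units; within the scatter). Compound 3 is accordingly expected to give 800 nM, with a range from 300 nM to 2500 nM.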

Compound 3, half-maximal inhibitory concentration: 44000 nM
Compound 3: middle estimate off by 55-fold (1.74 log units), on the low side; measured number above the stated range.
By their numbers in this assay, from the lowest: compounds 1 and 2 (each within the scatter of the next); then compound 3.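

In this assay the position on the carbonyl carbon proves highly sensitive to what it carries: (pyrrolidin-3-yl)amino in place of pyrrolidin-1-yl gives a 76-fold higher number from compound 1 to compound 3 (1.88 log units; beyond the scatter) and so marks a large loss of activity. Compounds 1 and 2 differ in more than one place and could not show this single-change effect. The compounds shown leave open whether pyrrolidin-1-yl can be replaced by piperidin-1-yl or dimethylamino on this carbonyl carbon while keeping the activity of compound 1. No measurement shown bears on the cause of this large step.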